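The compounds below may be only part of what the source reports. "The series", "measured", "known", "first", "only" and "open" are said of these compounds alone.

Within the data shown here, compound 1 `CCCCCCc1cc2c(=O)n(CC3CC3)cnc2s1` is the one compound with a numerical result in an ADME assay on HCT-116 cells (Homo sapiens) for cytotoxicity, read by MTT assay, with a stated time of 11 days; a higher number here means a weaker inhibitor of growth, a lower number a stronger inhibitor of growth; in this assay compound 1 gives 17.6 ug/mL. Compound 2 `CCCCCCCc1cc2c(=O)n(CC3CC3)cnc2s1` is recorded only as a limit of the assay, in this assay compound 2 giving > 100 ug/mL. Among the measured compounds shown here, the single measured step, an at least 5.6-fold higher number from compound 1 to compound 2 (0.75 log units; beyond the scatter), therefore runs from the one number into (the limit of > 100 ug/mL in this assay, at which 1 of the 2 values shown sits), and it concerns the hexyl chain rather than the group on the ring nitrogen. Compound 3 `CCCCCCc1cc2c(=O)n(CCN=[N+]=[N-])cnc2s1` differs from compound 1 by azidomethyl in place of cyclopropyl on a saturated chain carbon bound to an aromatic nitrogen. For the measured compounds named here, no measured step touches that position, so the only available step, the chain extension from compound 1 to compound 2, does not bear on it directly; the expectation is a step no larger than the scatter, with wide uncertainty. Compound 3 is estimated at 25 ug/mL, between 8 ug/mL and 100 ug/mL, meaning an expected step of a 1.4-fold higher number from compound 1 to compound 3 (0.15 log units; within the scatter).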

Compound 3, concentration for 50% growth inhibition: 14.7 ug/mL
Compound 3: middle estimate off by 1.7-fold (0.23 log units), on the high side, within the range that was stated.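

In this assay, among these compounds, azidomethyl in place of cyclopropyl on a saturated chain carbon bound to an aromatic nitrogen gives a 1.2-fold lower number from compound 1 to compound 3 (0.08 log units; within the scatter), the first measured step at this position. For this pair, the three-membered ring of carbon can give way to an open group with no ring and the read-out stays within the scatter, unlike the chain extension, which gives an at least 5.6-fold higher number from compound 1 to compound 2 (0.75 log units; beyond the scatter). The compounds shown offer no measured property that accounts for this outcome.

As far as these compounds go, it remains open whether an amine, a carboxylic acid or a longer chain in this place would also leave the number within the scatter. From the compounds shown here alone, it also remains open whether 2-azidoethyl in place of cyclopropylmethyl would behave the same way on the longer chain of compound 2.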